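The source may report more compounds than this note shows. Statements on the series, on what has been measured and on what is new or still open speak of the compounds shown alone.

In a functional assay on MCF7 cells (Homo sapiens) for inhibition, read by MTT assay, with a stated time of 48 h (a higher number here means a weaker inhibitor, a lower number a stronger inhibitor), compound 2 `c1ccc(-c2nn(-c3ccccc3)c3nccc(-c4cccs4)c23)cc1` gives 39300 nM and compound 3 `O=C(C=CNc1cc(-c2ccccc2)nn1-c1ccccc1)c1ccc(Br)cc1` gives 21700 nM, two values within the scatter of each other. Compound 1 `COc1ccc(-c2nc3c(c(-c4ccccc4)nn3-c3ccccc3)c(-c3ccc(N4CCCCC4)cc3)c2C#N)cc1` gives 2760 nM, a number lower than that of compound 2 by more than the scatter. Compound 2 therefore sits at the weak end of this small set, a place it shares with compound 3.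

The next structure is compound 4 `Cc1ccc(-c2ccnc3c2c(-c2ccccc2)nn3-c2ccccc2)cc1`, with the change 4-methylphenyl in place of thiophen-2-yl on an aromatic carbon, opposite the ring nitrogen. Going by the values given here, no measured pair here differs in one place only, so the size of this change has no direct precedent. Among the compounds with values here, the only anchor is compound 2 at 39300 nM. In this assay no step beyond the scatter is expected, with a slight lean towards a lower number. The estimated step is a 1.6-fold lower number from compound 2 to compound 4 (0.20 log units; within the scatter). Compound 4 is expected at 25000 nM, with an estimated range of 9000 nM to 70000 nM.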

Compound 4, half-maximal inhibitory concentration: 5590 nM
Compound 4: middle estimate off by 4.5-fold (0.65 log units), on the high side; measured number outside the range, below it.
By their numbers in this assay, from the lowest: compound 1; then compound 4; then compounds 3 and 2 (each within the scatter of the next).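

In this assay the aromatic carbon opposite the ring nitrogen responds to a change of group: 4-methylphenyl in place of thiophen-2-yl gives a 7.0-fold lower number from compound 2 to compound 4 (0.85 log units; beyond the scatter) with the rest of the core unchanged. Going by these compounds alone, this is the only step between compounds that differ in one place, which compound 1, compound 2 and compound 3 could not provide among themselves. Nothing measured here accounts for the size of this step.

On these data alone, with only these two groups compared at this carbon, it stays open whether the step follows from the six-membered ring or from its methyl, and a plain phenyl would separate the two. Also open, as far as these compounds go, is how this position takes a carboxylic acid or a longer chain in place of that methyl.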